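Changing the Double Bond Geometry of Compound 2

The source may hold more compounds than are shown below. What is called first, only, known or untested is meant among the compounds shown, and "the series" means these compounds.

Measured compounds:
compound 1 `O=C(/C(=C/c1ccc(Cl)cc1Cl)CCl)c1ccccc1` gives 15000 nM
compound 2 `CC(=O)OC/C(=C\c1ccc(Cl)cc1Cl)C(=O)c1ccccc1` gives 16000 nM
compound 3 `CC(=O)OC/C(=C\c1ccc(Cl)cc1Cl)C(=O)c1ccc(Cl)cc1` gives 4600 nM

In a functional assay on HeLa cells (Homo sapiens) for inhibition, read by sulforhodamine B assay, with a stated time of 48 h (on this read-out higher numbers stand for weaker inhibition of growth and lower numbers for stronger inhibition of growth), compound 2 stands at the highest of the three numbers. The acetoxy-for-chloro step a 1.1-fold higher number from compound 1 to compound 2 (0.03 log units; within the scatter) stays within the scatter, whereas the added aromatic chloro step a 3.5-fold lower number from compound 2 to compound 3 (0.54 log units; beyond the scatter) is a modest one beyond it. Compound 4 `CC(=O)OC/C(=C/c1ccc(Cl)cc1Cl)C(=O)c1ccccc1` differs from compound 2 only in geometry: the two compounds have the same atoms and bonds and differ only in configuration as drawn: 1 of 1 stereo elements differ; a double bond is drawn E in compound 2 and Z in compound 4. Going by the values given here, neither measured step touches the double bond geometry, so no measured step bears on this change, and the data give no guide to its size or direction. Compound 4 is therefore expected to show no step beyond the scatter, no change at the digits printed from compound 2 to compound 4 (within the scatter). Compound 4 is estimated at 16000 nM, within a range from 6000 nM to 40000 nM.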

Compound 4, concentration for 50% growth inhibition: 22000 nM
Compound 4: the middle estimate sits 1.4-fold (0.14 log units) below what was measured; the measured number falls inside the stated range.
By their numbers in this assay, from the lowest: compound 3; then compounds 1, 2 and 4 (each within the scatter of the next).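

Going by these compounds alone, the earlier steps left the double bond untouched, so this is the first reading on its geometry. In this assay, the change gives a 1.4-fold higher number from compound 2 to compound 4 (0.14 log units; within the scatter), so with the acetoxy group and the unsubstituted benzoyl side in place, the two drawn geometries cannot be told apart. The comparison isolates that single feature: the fact that compounds 2 and 4 differ only in the configuration as drawn

The compounds shown leave open whether geometry would matter as little alongside the added aromatic chloro of compound 3. They also leave open how either geometry would behave with an amine or a carboxylic acid in place of the acetoxy group.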